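Aryl trifluoromethyl added to a trifluoromethyl ketone chain

The source may report more compounds than this note shows. Statements on the series, on what has been measured and on what is new or still open speak of the compounds shown alone.

For the measured compounds named here, compound 3 `O=C(CCCCCCc1nc(-c2ccccc2)no1)C(F)(F)F` is the only member of this set with a number in an assay on isolated protein for inhibition of histone deacetylase 8 (Homo sapiens), read by fluorescence, with a stated time of 10 min (on this read-out lower numbers stand for stronger inhibition and higher numbers for weaker inhibition), in which compound 3 gives 760 nM. Compound 2 `Nc1ccccc1NC(=O)CCCCCCc1nc(-c2ccccc2)no1` carries the (2-aminophenyl)amino group on the carbonyl instead; in this assay compound 2 reaches only a limit, > 10000 nM. Compound 1 `O=C(CCCCCCc1nc(-c2ccc(C(F)(F)F)cc2)no1)NO` is the hydroxamic acid bearing the aryl trifluoromethyl; in this assay compound 1 also stops at a limit, > 10000 nM. Going by the values given here, the one measured step, an at least 13-fold lower number from compound 2 to compound 3 (1.11 log units; beyond the scatter), turns a limit into a number on exchanging the carbonyl substituent, and it rests on (the limit of > 10000 nM in this assay, at which 2 of the 3 values shown sit).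

Compound 4 `O=C(CCCCCCc1nc(-c2ccc(C(F)(F)F)cc2)no1)C(F)(F)F` differs from compound 3 by trifluoromethyl in place of hydrogen on an aromatic carbon. Among the compounds with values here, no measured step changes the aromatic ring alone; compound 1 and compound 3 differ in two places at once, so their two values show only a limit against a number. With nothing to guide the direction, the step is expected to stay within the scatter, a 1.2-fold higher number from compound 3 to compound 4 (0.07 log units; within the scatter). Compound 4 is therefore estimated at 900 nM, within 300 nM to 3000 nM.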

Compound 4, half-maximal inhibitory concentration: 1030 nM
Beside the measured number, compound 4's estimate is 1.1-fold (0.06 log units) below it, and the stated range covers the measured number.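

Trifluoromethyl in place of hydrogen on an aromatic carbon, para to a large group, is the first change at this position that can be read on its own, and in this assay it gives a 1.4-fold higher number from compound 3 to compound 4 (0.13 log units; within the scatter), which leaves compound 3 and compound 4 level within the scatter. With the aryl trifluoromethyl in place, the carbonyl substituent still counts, with trifluoromethyl in place of hydroxyamino giving an at least 9.7-fold lower number from compound 1 to compound 4 (0.98 log units; beyond the scatter). That step starts from compound 1, whose value is a limit of the assay and not a number, so its full size stays unknown: the limit of > 10000 nM in this assay, at which 2 of the 4 values shown sit.

The compounds shown leave open whether a chlorine or a methoxy group at this aromatic carbon would also stay within the scatter of compound 3. They also leave open how a shorter or longer chain would read with the trifluoromethyl ketone kept.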